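The source may report more compounds than this note shows. Statements on the series, on what has been measured and on what is new or still open speak of the compounds shown alone.

Compound 2 `Cn1ncc(Cl)c1-c1cc(C(=O)N[C@@H]2CN[C@H](CCN3CCC(O)CC3)C[C@H]2c2ccc(Cl)c(Cl)c2)oc1Cl` gives the highest of the three numbers in an assay for inhibition of RAC-alpha serine/threonine-protein kinase (Homo sapiens), read by HTRF, with a stated time of 1 h (a higher number here means a weaker inhibitor, a lower number a stronger inhibitor), at 5.99 nM. Compound 1 `Cn1ncc(Cl)c1-c1cc(C(=O)N[C@@H]2CN[C@H](CCNS(C)(=O)=O)C[C@H]2c2ccc(F)c(F)c2)oc1Cl` gives 3.29 nM, which lies within the scatter of compound 2, while compound 3 `CC(=O)NCC[C@@H]1C[C@@H](c2ccc(F)c(F)c2)[C@H](NC(=O)c2cc(-c3c(Cl)cnn3C)c(Cl)o2)CN1` gives 2.49 nM, the furthest from compound 2 and beyond the scatter. Compound 4 `Cn1ncc(Cl)c1-c1cc(C(=O)N[C@@H]2CN[C@H](CC(=O)O)C[C@H]2c2ccc(Cl)c(Cl)c2)oc1Cl` differs from compound 2 by carboxy in place of (4-hydroxypiperidin-1-yl)methyl on a saturated chain carbon bound to a saturated ring carbon. For the measured compounds named here, the only measured step, a 1.3-fold lower number from compound 1 to compound 3 (0.12 log units; within the scatter), concerns an exchange of acyl groups on an amine nitrogen and says nothing about replacing a ring-bearing chain with a carboxy. Going by the values given here, with no step that bears on this change, the expectation for compound 4 in this assay rests on the shared core alone, and a modest rise, a 2.0-fold higher number from compound 2 to compound 4 (0.30 log units; within the scatter), is estimated. Compound 4 is expected to give 12 nM, within 3 nM to 50 nM.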

Compound 4, half-maximal inhibitory concentration: 1.94 nM
The estimate for compound 4 lay 6.2-fold (0.79 log units) above the measured number, outside the stated range (below it).
By their numbers in this assay, from the lowest: compounds 4, 3, 1 and 2 (each within the scatter of the next, the first and the last beyond it).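

In this assay there is a 3.1-fold lower number from compound 2 to compound 4 (0.49 log units; beyond the scatter) when carboxy replaces (4-hydroxypiperidin-1-yl)methyl on a saturated chain carbon bound to a saturated ring carbon. This pair shows that the six-membered non-aromatic ring is not needed at this position to keep the number low, and that a much smaller group with no ring gives the lower number of the two. Nothing in the data shown accounts for this step. Still open, as far as these compounds go, is whether a methyl ester, a primary amide or a longer chain ending in a carboxylic acid would hold this number at the same position.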